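Methoxyphenyl for fluorophenyl on a shared imidazopyrazine core

A few compounds are considered here, and "the series" means these few. Any claim that something is new, unique, unknown or untested is made for them only; others in the source may bear on it.

In a functional assay on SK-MEL-5 cells (Homo sapiens) for inhibition, read by sulforhodamine B assay, with a stated time of 48 h, tested at 10 uM (on this read-out lower numbers stand for less inhibition and higher numbers for more inhibition at the one concentration tested (going by the name of the read-out)), compound 1 `Brc1cn2ccnc2c(-c2ccc3ncn(C4CCCCC4)c3c2)n1` gives 13.4%, and compound 2 `Fc1ccc(-c2cn3ccnc3c(-c3ccc4ncn(C5CCCCC5)c4c3)n2)cc1` gives 7.36%. Compound 2 stands lowest of the two numbers, with compound 1 its nearest neighbour, and the step of a number 6 percentage points lower from compound 1 to compound 2 (within the scatter) lies within the scatter, so the two are not told apart. Compound 3 `COc1ccccc1-c1cn2ccnc2c(-c2ccc3ncn(C4CCCCC4)c3c2)n1` carries 2-methoxyphenyl in place of 4-fluorophenyl on an aromatic carbon. For the measured compounds named here, the only measured step at that position, a number 6 percentage points lower from compound 1 to compound 2 (within the scatter), was small, and it concerns a different exchange, bromo for 4-fluorophenyl, so it bears only loosely on the present change. With both measured values low and no step beyond the scatter, compound 3 is expected to give a number close to compound 2, that is a step of a number 2.6 percentage points higher from compound 2 to compound 3 (within the scatter) in this assay, with no change beyond the scatter. Compound 3 is therefore estimated at 10%, in a range from 0% to 25%.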

Compound 3, a percentage reported as inhibition, at one concentration (the size of the read-out at that concentration, not a potency): 8.94%
For compound 3 the middle estimate is 1.1 percentage points above the measured one; low and high end bracket the measured number.
By their numbers in this assay, from the lowest: compounds 2, 3 and 1 (each within the scatter of the next).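

In this assay, the exchange of 4-fluorophenyl for 2-methoxyphenyl gives a number 1.6 percentage points higher from compound 2 to compound 3 (within the scatter), and the exchange of bromo for 2-methoxyphenyl gives a number 4.5 percentage points lower from compound 1 to compound 3 (within the scatter), so none of the three compounds can be told apart. Compared with the earlier pair, this adds a second aromatic ring at the same carbon, next to the ring nitrogen, with a different substituent and one hydrogen-bond acceptor, and still no step lies beyond the scatter. Nothing available explains this result.

The compounds shown leave open whether any group at this carbon can move the read-out beyond the scatter, for example an amine or a carboxylic acid. They also cannot separate the methoxy group from its place on the ring, which 4-methoxyphenyl would address.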